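Swapping a Chlorophenyl for a Hydroxyphenyl on a Sulfonamide

This account rests on a few compounds, and the source may have more. Where it says the series, first, only, none or still open, it means among the compounds named here.

Measured so far:
compound 1, `O=S(=O)(Nc1ccc2oc(-c3ccccc3)nc2c1)c1ccccc1O`, in an assay on cells for inhibition of HSP60/HSP10 (Homo sapiens), with a stated time of 60 min; on this read-out lower numbers stand for stronger inhibition and higher numbers for weaker inhibition: 85000 nM
compound 2, `O=S(=O)(Nc1ccc(-c2nc3ccccc3o2)cc1)c1cccc(Cl)c1`, in this assay: 54000 nM

Both measured compounds are weak in this assay. Compound 2 stands at one end of this pair, but its gap to compound 1 lies within the usual scatter, so the two numbers cannot be told apart. The two structures also differ in more than one place, so no single step can be read from them.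

Compound 3, `O=S(=O)(Nc1ccc(-c2nc3ccccc3o2)cc1)c1ccc(O)cc1`, is the next compound. Relative to compound 2 the change is 4-hydroxyphenyl in place of 3-chlorophenyl on a sulfonyl sulfur. Within the data shown here, no measured pair shows this change, and compound 1 carries its hydroxyl in a different arrangement, so it offers no guide. Compound 3 is therefore expected to stay close to compound 2, with the step of a 1.3-fold higher number from compound 2 to compound 3 (0.11 log units; within the scatter) expected to lie within the scatter. Compound 3 is estimated at 70000 nM, with a range from 25000 nM to 200000 nM.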

Compound 3, half-maximal inhibitory concentration: 78000 nM
Estimate against measurement, compound 3: 1.1-fold (0.05 log units) below; the range from low to high includes it.
By their numbers in this assay, from the lowest: compounds 2, 3 and 1 (each within the scatter of the next).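

Among these compounds, exchanging 3-chlorophenyl for 4-hydroxyphenyl on a sulfonyl sulfur gives a 1.4-fold higher number from compound 2 to compound 3 (0.16 log units; within the scatter) in this assay, the first comparison here that differs in one place only. The two numbers cannot be told apart, even though the entering group carries 1 hydrogen-bond donor and 1 hydrogen-bond acceptor and the leaving group carries neither. No measurement shown offers an explanation for this result.

The compounds shown leave open whether 3-hydroxyphenyl or 4-chlorophenyl on the sulfonyl sulfur would give a number that differs from these two, which would separate the identity of the group from its arrangement on the ring. They also leave open whether a different group at this place, such as an amine or a carboxylic acid, would give a step beyond the scatter.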